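This account rests on a few compounds, and the source may have more. Where it says the series, first, only, none or still open, it means among the compounds named here.

Measured compounds:
compound 1 `COc1cc(-c2cc(/C=C/C(=O)c3ccc(Cl)c(Cl)c3)[nH]n2)cc(OC)c1OC` gives 4900 nM in a functional assay on NCI-H460 cells (Homo sapiens) for inhibition, read by sulforhodamine B assay, with a stated time of 48 h; a higher number here means a weaker inhibitor of growth, a lower number a stronger inhibitor of growth;
compound 2 `COc1ccc(-c2cc(/C=C/C(=O)c3cc(OC)c(OC)c(OC)c3)[nH]n2)cc1OC` gives 1040 nM in this assay;
compound 3 `COc1ccc(-c2cc(/C=C/C(=O)c3ccc(N)cc3)[nH]n2)cc1` gives 2070 nM in this assay.

Among these three, compound 2 has the lowest number. Its nearest neighbour is compound 3, whose value lies within the usual scatter of this value, so no order between the two can be claimed. Compound 1 stands further off, beyond the scatter, with a clearly higher number than compound 2.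

Compound 4 `COc1cc(C(=O)/C=C/c2cc(-c3cc(OC)c(OC)c(OC)c3)n[nH]2)cc(OC)c1OC` is not yet measured. It differs from compound 2 by a single change: methoxy in place of hydrogen on an aromatic carbon. Among the measured compounds shown here, since no measured pair shows this change, the expectation rests on compound 2 alone. The step is expected to be small, with no change beyond the scatter in this assay in either direction, the expected step being a 1.0-fold lower number from compound 2 to compound 4 (0.02 log units; within the scatter). For compound 4 the estimated value is 1000 nM, with a range from 400 nM to 2600 nM.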

Compound 4, concentration for 50% growth inhibition: 1890 nM
For compound 4 the middle estimate is 1.9-fold (0.28 log units) below the measured one; measured number inside the range.
By their numbers in this assay, from the lowest: compounds 2, 4 and 3 (each within the scatter of the next); then compound 1.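

In this assay, methoxy in place of hydrogen on an aromatic carbon, ortho to a methoxy group, gives a 1.8-fold higher number from compound 2 to compound 4 (0.26 log units; within the scatter). Among the compounds shown here, this position therefore takes an added methoxy group with no change that can be told from scatter, something the earlier compounds could not show, since no two of them differed in one place. Nothing measured here explains this result.

On these data alone, whether a hydroxyl group, a fluorine atom or a longer ether such as ethoxy would fit this carbon equally well remains open. So does whether a group on this carbon can move the number beyond the scatter at all.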